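A few compounds are considered here, and "the series" means these few. Any claim that something is new, unique, unknown or untested is made for them only; others in the source may bear on it.

Working notes on the series.

For the measured compounds named here, compound 1, `O=C(NC(=S)Nc1ccc(F)cc1)c1cn(-c2ccccc2)nc1-c1ccc(F)cc1`, sits with the highest number of the three compounds measured so far in a functional assay on A549 cells (Homo sapiens) for inhibition, read by CCK-8 assay, with a stated time of 48 h (on this read-out lower numbers stand for stronger inhibition and higher numbers for weaker inhibition), giving 3540 nM. Compound 2, `COc1ccc(NC(=S)NC(=O)c2cn(-c3ccccc3)nc2-c2ccc(OC)cc2)cc1`, gives 750 nM in this assay, and compound 3, `COc1ccc(-c2nn(-c3ccccc3)cc2C(=O)NC(=S)Nc2ccc(Cl)cc2)cc1`, gives 1310 nM. The only single-point step among these is a 1.7-fold higher number from compound 2 to compound 3 (0.24 log units; within the scatter), where the swap sits on the aryl attached to the thiourea nitrogen rather than on the aryl attached to the core.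

Compound 4, `O=C(NC(=S)Nc1ccc(F)cc1)c1cn(-c2ccccc2)nc1-c1ccc(Cl)cc1`, is not yet measured. It differs from compound 1 in one place: chloro in place of fluoro on an aromatic carbon. Going by the values given here, no measured step in this assay changes the 4-fluorophenyl to 4-chlorophenyl on this side of the core, so the step from compound 2 to compound 3 is only a loose guide, and it was itself within the scatter. The expectation is therefore no step beyond the scatter from compound 1, with the estimate for compound 4 in this assay set at 3000 nM and a range of 1200 nM to 7500 nM. This estimate corresponds to a 1.2-fold lower number from compound 1 to compound 4 (0.07 log units; within the scatter).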

Compound 4, half-maximal inhibitory concentration: 3980 nM
Compound 4: middle estimate off by 1.3-fold (0.12 log units), on the low side; the range from low to high includes it.
By their numbers in this assay, from the lowest: compounds 2 and 3 (each within the scatter of the next); then compounds 1 and 4 (each within the scatter of the next).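

In this assay, for the compounds shown here, chloro in place of fluoro on an aromatic carbon, para to a large group, gives a 1.1-fold higher number from compound 1 to compound 4 (0.05 log units; within the scatter), the first step read at this place; the earlier step, a 1.7-fold higher number from compound 2 to compound 3 (0.24 log units; within the scatter), changed the aryl attached to the thiourea nitrogen. With the 4-fluorophenyl on the thiourea side held fixed, the two halogens cannot be told apart at this place, so this exchange gives no handle on the number in this cell read-out. No supporting measurement bears on this result.

Going by these compounds, whether an amine or a carboxylic acid at this place would give a step beyond the scatter stays open. Also open, on these data alone, is whether the same halogen exchange reads alike with another group on the thiourea-side aryl, as compounds 2 and 3 differ from compound 1 in more than one place.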